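From Methyl to Cyclopropyl on the Amino Nitrogen

The source may report more compounds than this note shows. Statements on the series, on what has been measured and on what is new or still open speak of the compounds shown alone.

- compound 1 `CCCNc1nc(Nc2ccc(OC)cc2)nc2ccccc12`: 5090 nM
- compound 2 `CNc1nc(Nc2ccc(OC)cc2)nc2ccccc12`: 17500 nM

In a functional assay on KBVIN cells (Homo sapiens) for antiproliferative activity, read by sulforhodamine B assay, with a stated time of 48 h (a higher number here means a weaker inhibitor of growth, a lower number a stronger inhibitor of growth), compound 2, at 17500 nM, has the higher of the two numbers and is the weaker inhibitor of growth. Compound 3 `COc1ccc(Nc2nc(NC3CC3)c3ccccc3n2)cc1` has not yet been measured. It differs from compound 2 by cyclopropyl in place of methyl on a nitrogen on an aromatic ring, with cyclopropyl in place of methyl on a nitrogen on an aromatic ring. Among the compounds with values here, the one measured step that bears on this is a 3.4-fold higher number from compound 1 to compound 2 (0.54 log units; beyond the scatter), where hydrogen replaces ethyl on the chain. Reading that step in reverse, a modest drop is expected in this assay. The expected change is a 2.2-fold lower number from compound 2 to compound 3 (0.34 log units; beyond the scatter). Compound 3 is estimated at 8000 nM, within an expected range of 3000 nM to 20000 nM.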

Compound 3, concentration for 50% growth inhibition: 13400 nM
Compound 3: the middle estimate sits 1.7-fold (0.22 log units) below what was measured; the range from low to high includes it.
By their numbers in this assay, from the lowest: compound 1; then compounds 3 and 2 (each within the scatter of the next).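

In this assay, cyclopropyl in place of methyl on the nitrogen gives a 1.3-fold lower number from compound 2 to compound 3 (0.12 log units; within the scatter), so at this position the two groups cannot be told apart. Cyclopropyl in place of propyl gives a 2.6-fold higher number from compound 1 to compound 3 (0.42 log units; beyond the scatter), which shows that the open propyl chain and the cyclopropyl ring are not interchangeable here. Nothing measured on these compounds accounts for this difference. As far as these compounds go, what remains open is how a longer chain such as butyl, a branched isopropyl or a larger cyclobutyl ring would read on this nitrogen.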